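A few compounds are considered here, and "the series" means these few. Any claim that something is new, unique, unknown or untested is made for them only; others in the source may bear on it.

In a functional assay on HUVEC cells (Homo sapiens) for inhibition, with a stated time of 4 days (a lower number here means a stronger inhibitor, a higher number a weaker inhibitor), compound 1 `Cc1cc(OCc2cccc(C#N)c2)ccc1Cl` gives 11000 nM and compound 2 `COC(=O)c1ccc(OC)c(COc2ccc(Cl)c(C)c2)c1` gives 2300 nM. Compound 3 `COc1ccc(C(N)=O)cc1/C=C/c1ccc(Br)cc1` gives 560 nM, the lowest number of the three and beyond the scatter from both others. Compound 4 `COc1ccc(/C=C/c2cc(C(N)=O)ccc2OC)cc1` has not yet been measured. It carries methoxy in place of bromo on an aromatic carbon, para to a large group: methoxy in place of bromo on an aromatic carbon. Among the compounds with values here, no pair of measured compounds differs in one place, so the data show no direct precedent for this swap. A small step toward a higher number, within the scatter, is expected, estimated as a 1.6-fold higher number from compound 3 to compound 4 (0.21 log units; within the scatter). For compound 4 the expected value is 900 nM, with an estimated range from 250 nM to 3200 nM.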

Compound 4, half-maximal inhibitory concentration: 8800 nM
Beside the measured number, compound 4's estimate is 9.8-fold (0.99 log units) below it; the measured number lies above the stated range.
By their numbers in this assay, from the lowest: compound 3; then compound 2; then compounds 4 and 1 (each within the scatter of the next).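

In this assay methoxy in place of bromo on an aromatic carbon, para to a large group, brings a 16-fold higher number from compound 3 to compound 4 (1.20 log units; beyond the scatter) and so shows that this position is sensitive to the group it carries. The earlier compounds shown here offered no single-place comparison that could show this. No measured evidence accounts for the size of this step.

The compounds shown leave open whether another group here, such as fluoro or an amine, would keep the number near that of compound 3. They also leave open whether the same swap would have a similar effect on another core.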